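The source may hold more compounds than are shown below. What is called first, only, known or untested is meant among the compounds shown, and "the series" means these compounds.

Three compounds share one core and differ only in the aromatic group attached to the saturated ring. Compound 1 `COc1cc(C(F)(F)F)cc(SC)c1C(=O)NC1(c2ccccc2)CCCN(C)C1` gives 24 nM in an assay on cells for inhibition of sodium- and chloride-dependent glycine transporter 1 (Homo sapiens); a lower number here means that less compound is needed, a higher number that more compound is needed for the effect; compound 2 `COc1cc(C(F)(F)F)cc(SC)c1C(=O)NC1(c2ccc(F)cc2)CCCN(C)C1` gives 26 nM; compound 3 `COc1cccc(C2(NC(=O)c3c(OC)cc(C(F)(F)F)cc3SC)CCCN(C)C2)c1` gives 110 nM, the highest number of the three. The steps show a pattern: a 1.1-fold higher number from compound 1 to compound 2 (0.03 log units; within the scatter), whereas a 4.6-fold higher number from compound 1 to compound 3 (0.66 log units; beyond the scatter) and a 4.2-fold higher number from compound 2 to compound 3 (0.63 log units; beyond the scatter). So a methoxy on that ring costs, while fluoro does not.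

Compound 4 `COc1cc(C(F)(F)F)cc(SC)c1C(=O)NC1(c2cccnc2)CCCN(C)C1` is the next step from compound 3: pyridin-3-yl in place of 3-methoxyphenyl on a saturated ring carbon. Going by the values given here, this removes the methoxy that made compound 3 the weakest of the three, and exchanges one ring carbon for a nitrogen, a change for which no measured pair gives a direct guide. Because a 4.6-fold higher number from compound 1 to compound 3 (0.66 log units; beyond the scatter) was the penalty for the methoxy, its loss is expected to win back part of that, but with an uncertainty that the nitrogen adds. For compound 4 the expected step is a 2.2-fold lower number from compound 3 to compound 4 (0.34 log units; beyond the scatter), and its estimated value is 50 nM with a likely range from 20 nM to 150 nM.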

Compound 4, half-maximal effective concentration: 54 nM
Beside the measured number, compound 4's estimate is 1.1-fold (0.03 log units) below it; the measured number falls inside the stated range.
By their numbers in this assay, from the lowest: compounds 1 and 2 (each within the scatter of the next); then compound 4; then compound 3.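

At this saturated ring carbon, pyridin-3-yl gives a middle result in this assay: there is a 2.0-fold lower number from compound 3 to compound 4 (0.31 log units; beyond the scatter) as 3-methoxyphenyl leaves, but also a 2.3-fold higher number from compound 1 to compound 4 (0.35 log units; beyond the scatter) and a 2.1-fold higher number from compound 2 to compound 4 (0.32 log units; beyond the scatter) against the two best groups. The step from compound 1 is the informative one, as it exchanges a single ring carbon for a nitrogen and still moves the number beyond the scatter, whereas fluoro on the phenyl ring left the number within the scatter. So not every small change to this aromatic ring is tolerated, and nothing measured here bears on what lies behind these differences.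

Whether the place of the ring nitrogen matters remains open, as pyridin-2-yl and pyridin-4-yl are not among these compounds. So does whether a methoxy carries the same cost as 4-methoxyphenyl, or an amine on the ring would behave differently.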